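Hydroxy for Fluoro on the Aryl Urea of Compound 1

The source may report more compounds than this note shows. Statements on the series, on what has been measured and on what is new or still open speak of the compounds shown alone.

Three compounds built on the core of compound 1 `COc1cc(NC(C)CCCNC(=O)Nc2ccc(F)cc2)c2ncccc2c1` have been measured in a functional assay on MIA PaCa-2 cells (Homo sapiens) for inhibition, read by MTT assay, with a stated time of 72 h; on this read-out higher numbers stand for weaker inhibition and lower numbers for stronger inhibition. Compound 1 gives 21000 nM, the second highest of the three numbers. For the measured compounds named here, compound 2 `COc1cc(NC(C)CCCNC(=O)NNC(=O)Nc2cccc(Cl)c2)c2ncccc2c1` gives 74000 nM, and the step of a 3.5-fold higher number from compound 1 to compound 2 (0.55 log units; beyond the scatter) is the only single-place change among the measured compounds. Compound 3 `COc1cc(NC(C)CCCNC(=O)NNC(=O)Nc2cc(C(F)(F)F)cc(C(F)(F)F)c2)c2ncccc2c1` gives 20000 nM, so compound 1 and compound 3 lie within the scatter of each other.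

Compound 4 `COc1cc(NC(C)CCCNC(=O)Nc2ccc(O)cc2)c2ncccc2c1` has not yet been measured. It differs from compound 1 by hydroxy in place of fluoro on an aromatic carbon. Going by the values given here, no measured step touches this part of the molecule: the step from compound 1 to compound 2 alters a different region, and compound 2 and compound 3 differ from each other elsewhere as well, so neither pair speaks to a hydroxy in place of a fluoro. With nothing to draw on, the change is expected to bring no step beyond the scatter, a 1.2-fold higher number from compound 1 to compound 4 (0.08 log units; within the scatter). Compound 4 is therefore estimated at 25000 nM, within a range of 8000 nM to 75000 nM.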

Compound 4, half-maximal inhibitory concentration: 57000 nM
The estimate for compound 4 lay 2.3-fold (0.36 log units) below the measured number; the range from low to high includes it.
By their numbers in this assay, from the lowest: compounds 3 and 1 (each within the scatter of the next); then compounds 4 and 2 (each within the scatter of the next).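

For the compounds shown here, on the aryl urea, the step of a 2.7-fold higher number from compound 1 to compound 4 (0.43 log units; beyond the scatter) in this assay shows that this place, para to a large group, responds to the exchange of a single atom, which no earlier step could show. The step of a 1.3-fold lower number from compound 2 to compound 4 (0.11 log units; within the scatter) then shows that hydroxy on this ring ends within the scatter of the replacement of the whole 4-fluorophenyl group by ((3-chlorophenyl)carbamoyl)amino. No measurement is at hand that would account for this shift.

Going by these compounds, what an amine or a carboxylic acid would do at this same aromatic carbon remains open. Only hydroxy has been measured in place of fluoro there. Whether another group would give a step of the same size is not known.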